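The compounds below may be only part of what the source reports. "The series", "measured", "known", "first", "only" and "open" are said of these compounds alone.

Compound 1 `Nc1ncn(C[C@H]2CO[C@H](CO)O2)c(=O)n1`: 70000 nM
Compound 2 `Cc1nn(C[C@@H]2CO[C@H](CO)O2)c(=O)[nH]c1=O`: > 100000 nM

Both compounds were tested in a functional assay on L1210 cells (Mus musculus); on this read-out higher numbers stand for an effect only at larger amounts of compound and lower numbers for an effect already at smaller amounts. Compound 1 gives 70000 nM, so its effect appears only at a large amount of compound. Compound 2 gives > 100000 nM, which is a limit of the assay and not a number. It stands at the limit of > 100000 nM in this assay, at which 1 of the 2 values shown sits.

Compound 3 `Cc1nn(C[C@H]2CO[C@H](CO)O2)c(=O)[nH]c1=O` has not been measured yet. Set against compound 2, the change is small on paper: the two compounds have the same atoms and bonds and differ only in configuration as drawn: 1 of 2 stereo elements differ; a stereocentre at a saturated ring carbon is drawn R in compound 2 and S in compound 3. A stereocentre at a saturated ring carbon is drawn R in compound 2 and S in compound 3, and all atoms and bonds stay the same.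

For the measured compounds named here, no measured pair shows what such a switch does in this assay, so no step beyond the usual scatter is expected, in either direction. The expected change is a number no higher from compound 2 to compound 3 (the limit leaves the size open). Compound 3 is estimated at 100000 nM, with an expected range from 40000 nM to 200000 nM.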

Compound 3, half-maximal effective concentration: > 100000 nM
Compound 3: a limit, no number; the forecaster's own chance of this, stated with the estimate: 70%; the middle value lies on the limit itself.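

For the compounds shown here, compound 2 and compound 3 both stop at a limit of the assay, not at a number, and no step between them can be read. From the compounds shown here alone, what the switch of the one stereocentre at a saturated ring carbon does in this assay stays open.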